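The compounds below may be only part of what the source reports. "The series", "measured", "known", "first", "only" and "open" are said of these compounds alone.

Compound 1, `CCCCn1ccc(-c2ccc(Oc3ccnc(C)c3)cc2)c(C#N)c1=O`, is the stronger of the two measured compounds: in a functional assay on CHO cells for positive allosteric modulation of metabotropic glutamate receptor 2 (Homo sapiens), read by scintillation counting and GTPgammaS binding, with a stated time of 30 min (a higher number here means that more compound is needed for the effect, a lower number that less compound is needed), compound 1 gives 398 nM, the lowest of the two numbers recorded. Among the measured compounds shown here, its only measured neighbour is compound 2, `Cc1cc(Oc2ccc(-c3ccn(CC4CC4)c(=O)c3C#N)cc2)ccn1`, which in this assay gives 832 nM; the single step between them, a 2.1-fold higher number from compound 1 to compound 2 (0.32 log units; beyond the scatter), swaps cyclopropyl in place of propyl on a saturated chain carbon bound to an aromatic nitrogen.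

Compound 3, `CCCCn1ccc(-c2ccc(Oc3cccnc3C)cc2)c(C#N)c1=O`, departs from compound 1 at a different spot: 2-methylpyridin-3-yl in place of 2-methylpyridin-4-yl on an oxygen on an aromatic ring. The group keeps the same atoms but is joined to the oxygen through another ring position. For the measured compounds named here, the one measured step concerns the chain on the aromatic nitrogen, not this oxygen-linked group, so no measured step bears directly on the change from compound 1 to compound 3. Lacking a comparable pair, the expectation for compound 3 is only a modest shift from compound 1, with the direction uncertain and possibly none beyond the scatter, that is a 1.5-fold higher number from compound 1 to compound 3 (0.18 log units; within the scatter). In this assay compound 3 is therefore expected to give about 600 nM, within a range of 150 nM to 2500 nM.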

Compound 3, half-maximal effective concentration: 347 nM
Compound 3: the middle estimate sits 1.7-fold (0.24 log units) above what was measured, within the range that was stated.
By their numbers in this assay, from the lowest: compounds 3 and 1 (each within the scatter of the next); then compound 2.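

In this assay, joining the oxygen through 2-methylpyridin-3-yl in place of 2-methylpyridin-4-yl gives a 1.1-fold lower number from compound 1 to compound 3 (0.06 log units; within the scatter) and so leaves the two compounds indistinguishable, although they have the same atoms joined differently. Among the compounds shown here, the earlier pair spoke only to the chain on the aromatic nitrogen, whereas this pair gives the first reading at the group on the oxygen: with the rest of compound 1 kept, these two attachment points of the methylpyridine cannot be told apart in this measurement. Nothing available here explains why the two numbers lie so close together.

The compounds shown leave open whether the two attachment points would also match with the cyclopropyl group of compound 2 on the chain, since that combination appears in neither compound 1 nor compound 3. They also leave open how far this tolerance extends, for instance whether a plain phenyl ring, a pyridine without its methyl group or a methylpyridine joined through its remaining ring positions would give a similar number on the same oxygen.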